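Chloro for Bromo on a Ketone-Bearing Core

The source may hold more compounds than are shown below. What is called first, only, known or untested is meant among the compounds shown, and "the series" means these compounds.

Compound 1 `C=C1C[C@]23C[C@@]1(O)CC[C@H]2c1ccc(OS(=O)(=O)c2ccc(C)cc2)c(C)c1[C@@H]3Cn1cc(-c2ccc(Cl)cc2)nn1`: in a functional assay on A549 cells (Homo sapiens) for cytotoxicity, read by MTT assay, with a stated time of 4 days (on this read-out lower numbers stand for stronger inhibition and higher numbers for weaker inhibition), compound 1 gives > 20000 nM, a limit of the assay.
Compound 2 `C=C1C(=O)[C@]23C[C@@]1(O)CC[C@H]2c1ccc(OS(=O)(=O)c2ccc(C)cc2)c(C)c1[C@@H]3Cn1cc(-c2ccc(Br)cc2)nn1`: in this assay compound 2 gives 1630 nM.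
Compound 3 `C=C1C[C@]23C[C@@]1(O)CC[C@H]2c1ccc(OS(=O)(=O)c2ccc(C)cc2)c(C)c1[C@@H]3Cn1cc(-c2ccc(Br)cc2)nn1`: in this assay compound 3 gives > 20000 nM, a limit of the assay.

Compound 2 is the only one of the three with a plain number; the other two values are limits, not numbers. The change from compound 3 to compound 1 is chloro in place of bromo on an aromatic carbon, and the step it made, a step that the two limits leave unreadable from compound 3 to compound 1, cannot be sized because both compounds sit at the limit of > 20000 nM in this assay, at which 2 of the 3 values shown sit. The difference between the core of compound 2 and the core of compound 3 is not broken down here.

Compound 4 `C=C1C(=O)[C@]23C[C@@]1(O)CC[C@H]2c1ccc(OS(=O)(=O)c2ccc(C)cc2)c(C)c1[C@@H]3Cn1cc(-c2ccc(Cl)cc2)nn1` carries the same change made on the core of compound 2: chloro in place of bromo on an aromatic carbon. The place of the change is described in the same words for both pairs, so this is the same change, here on a core that does give a readable number. With the earlier step unreadable, the expectation rests on compound 2 alone, which gives 1630 nM in this assay, and on the change itself being one small halogen for another. The step from compound 2 to compound 4 is therefore expected to be small, a 1.4-fold higher number from compound 2 to compound 4 (0.15 log units; within the scatter). Compound 4 is estimated at 2300 nM in this assay, with a likely range from 800 nM to 7000 nM.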

Compound 4, half-maximal inhibitory concentration: 1870 nM
Compound 4: middle estimate off by 1.2-fold (0.09 log units), on the high side; the range from low to high includes it.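

On the core of compound 2, the swap of bromo for chloro on the aromatic carbon gives a 1.1-fold higher number from compound 2 to compound 4 (0.06 log units; within the scatter) in this assay, so this pair cannot be told apart on this read-out. This does not show that the change behaves the same way on both cores, because the matching pair, compound 3 and compound 1, offers two limits and no numbers, which leaves its step unreadable: the limit of > 20000 nM in this assay, at which 2 of the 4 values shown sit. What remains is a single readable example of the change, on one core and in one cell line, and one pair can show neither a rule for the series nor how the change would read on any further core.

The compounds shown carry only bromo or chloro on this aromatic carbon, so it remains open whether the position tolerates groups that are unlike a halogen, such as an amine, a carboxylic acid or a longer chain such as butoxy. Going by these compounds, it also remains open whether the match between compound 2 and compound 4 would hold in cell lines other than the one used here.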